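The source may hold more compounds than are shown below. What is called first, only, known or untested is meant among the compounds shown, and "the series" means these compounds.

Of the compounds shown here, three have been measured in an ADME assay on Vero cells (Chlorocebus sabaeus) for cytotoxicity, read by resazurin assay, with a stated time of 3 days; a lower number here means a stronger inhibitor, a higher number a weaker inhibitor. Compound 1, `CN(C)c1cc2[nH]c(C3CCCCC3)nc2cc1NC(=O)c1ccc(F)cc1`, reaches only a limit of the assay rather than a number: in this assay compound 1 gives > 100 ug/mL. Compound 2, `CCCN(CCC)c1cc2[nH]c(C3CCCCC3)nc2cc1NC(=O)c1ccccc1`, likewise stops at a limit, and in this assay compound 2 gives > 100 ug/mL. Compound 3, `O=C(CCc1ccccc1)Nc1cc2nc(C3CCCCC3)[nH]c2cc1N1CCCC1`, also stops at a limit, and in this assay compound 3 gives > 100 ug/mL. Compound 3 thus stands where every measured compound stands, at the limit of > 100 ug/mL in this assay, at which 3 of the 3 values shown sit; no order among the three can be read from these values.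

Compound 4, `CCCCCC(=O)Nc1cc2nc(C3CCCCC3)[nH]c2cc1N1CCCC1`, has not yet been measured in this assay. It differs from compound 3 in one place: propyl in place of phenyl on a saturated chain carbon, two bonds along the chain from a carbonyl carbon. For the measured compounds named here, no step between measured compounds is available to set the size of this change. Since all three measured values sit at a limit, the expected step is a step that the limit leaves unreadable from compound 3 to compound 4, none beyond the scatter. Compound 4 is therefore expected to give about 120 ug/mL in this assay, within a range from 60 ug/mL to 300 ug/mL, and most probably to return only a limit again.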

Compound 4, half-maximal inhibitory concentration: > 100 ug/mL
Compound 4: no number, only a limit; the forecaster's own chance of this, stated with the estimate: 85%; the middle value does not contradict the limit.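

For the compounds shown here, compound 3 and compound 4 each return only a limit in this assay, so no step between them can be read. The compounds shown leave open how far any of them lies past that limit, and whether any change to them would yield a number: the limit of > 100 ug/mL in this assay, at which 4 of the 4 values shown sit.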